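The source may hold more compounds than are shown below. What is called first, only, known or untested is meant among the compounds shown, and "the series" means these compounds.

Measured compounds:
- compound 1 `COc1cc(-c2nnc(SCC(=O)c3ccc(C(F)(F)F)cc3)n2N)cc(OC)c1OC`: 3380 nM in a functional assay on HeLa cells (Homo sapiens) for antiproliferative activity, read by MTT assay, with a stated time of 48 h; a higher number here means a weaker inhibitor, a lower number a stronger inhibitor
- compound 2 `COc1cc(-c2nnc(SCC(=O)c3ccc(F)cc3)n2N)cc(OC)c1OC`: 20900 nM
- compound 3 `COc1cc(-c2nnc(SCC(=O)Nc3ccccc3)n2N)cc(OC)c1OC`: 8280 nM

Compound 1 stands lowest of the three numbers in this assay; compound 3 is nearest and compound 2 furthest. The piece now follows the move to compound 4 `COc1cc(-c2nnc(SCC(=O)Nc3ccccc3F)n2N)cc(OC)c1OC`, which differs from compound 1 as follows: (2-fluorophenyl)amino in place of 4-(trifluoromethyl)phenyl on a carbonyl carbon. The closest measured step is the one to the plain anilide, a 2.4-fold higher number from compound 1 to compound 3 (0.39 log units; beyond the scatter), a modest rise. The trifluoromethyl itself also mattered, since a 6.2-fold higher number from compound 1 to compound 2 (0.79 log units; beyond the scatter), though that change sat on a ketone-linked ring, not an anilide. Among the compounds with values here, no measured pair shows a fluorine added to the anilide ring, so compound 4 is expected to sit near compound 3, with a modest rise from compound 1 of about a 2.4-fold higher number from compound 1 to compound 4 (0.37 log units; beyond the scatter). Compound 4 is therefore estimated at 8000 nM, within 3000 nM to 25000 nM.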

Compound 4, half-maximal inhibitory concentration: 38200 nM
Compound 4: the middle estimate sits 4.8-fold (0.68 log units) below what was measured, and the stated range ends below it.
By their numbers in this assay, from the lowest: compound 1; then compound 3; then compounds 2 and 4 (each within the scatter of the next).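

In this assay, adding a fluoro to the anilide ring was not a neutral change (a 4.6-fold higher number from compound 3 to compound 4 (0.66 log units; beyond the scatter)), and the replacement of 4-(trifluoromethyl)phenyl by (2-fluorophenyl)amino proved a large step overall (an 11-fold higher number from compound 1 to compound 4 (1.05 log units; beyond the scatter)). Compound 4 and the 4-fluorophenyl ketone compound 2 cannot be told apart (a 1.8-fold higher number from compound 2 to compound 4 (0.26 log units; within the scatter)). Nothing measured here accounts for the effect of this fluoro.

Going by these compounds, whether a trifluoromethyl, chloro or methoxy group on the anilide ring would give a number nearer that of compound 1 remains open.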